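Five-membered heteroaryl in place of halophenyl: paw edema notes

The compounds below may be only part of what the source reports. "The series", "measured", "known", "first", "only" and "open" are said of these compounds alone.

Measured so far:
compound 1 `NS(=O)(=O)c1ccc2nc(-n3nc(C(F)(F)F)cc3-c3ccc(Br)cc3)sc2c1`: 43%
compound 2 `NS(=O)(=O)c1ccc2nc(-n3nc(C(F)(F)F)cc3-c3ccc(Cl)cc3)sc2c1`: 42%
compound 3 `NS(=O)(=O)c1ccc2nc(-n3nc(C(F)(F)F)cc3-c3ccco3)sc2c1`: 54%

In a functional assay on the whole organism (strain Wistar albino) for inhibition, with Rattus norvegicus as the target, read by paw edema, with stated times of 30 min and 4 h, at a dose of 50 mg/kg by the oral route (on this read-out higher numbers stand for more inhibition at the one dose given (going by the name of the read-out) and lower numbers for less inhibition), compound 2 gives 42%, the lowest of the three numbers, though compound 1 lies within the scatter of it, a number 1 percentage points lower from compound 1 to compound 2 (within the scatter). Compound 3 stands furthest away, a number 12 percentage points higher from compound 2 to compound 3 (beyond the scatter). Compound 4 `NS(=O)(=O)c1ccc2nc(-n3nc(C(F)(F)F)cc3-c3cccs3)sc2c1` is not yet measured; it differs from compound 2 by thiophen-2-yl in place of 4-chlorophenyl on an aromatic carbon. Among the measured compounds shown here, the steps that bear on it are those to the other five-membered heteroaryl, a number 12 percentage points higher from compound 2 to compound 3 (beyond the scatter) and a number 11 percentage points higher from compound 1 to compound 3 (beyond the scatter), both modest and beyond the scatter. Compound 4 is expected to follow with a similar modest rise, a number 9 percentage points higher from compound 2 to compound 4 (within the scatter), because of a number 12 percentage points higher from compound 2 to compound 3 (beyond the scatter). Compound 4 is estimated at 51%, within a range of 41% to 61%.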

Compound 4, a percentage reported as inhibition, in the whole organism at one dose (the size of the read-out at that dose, not a potency): 15%
The estimate for compound 4 lay 36 percentage points above the measured number; the whole stated range lies above it.
By their numbers in this assay, from the lowest: compound 4; then compounds 2 and 1 (each within the scatter of the next); then compound 3.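

In this assay, this position does not treat the two five-membered aromatic rings alike: thiophen-2-yl in place of furan-2-yl gives a number 39 percentage points lower from compound 3 to compound 4 (beyond the scatter), so the gain seen with furan-2-yl does not carry over to thiophen-2-yl. Against the halophenyl compounds, thiophen-2-yl gives a number 27 percentage points lower from compound 2 to compound 4 (beyond the scatter) and a number 28 percentage points lower from compound 1 to compound 4 (beyond the scatter), so the five-membered rings fall on both sides of the halophenyl compounds. No measurement here accounts for the gap between furan-2-yl and thiophen-2-yl.

Still open, as far as these compounds go, is whether a ring such as pyrrol-2-yl or thiazol-2-yl at this position would side with furan-2-yl or with thiophen-2-yl. Also open, from the compounds shown here alone, is what a methyl or a carboxylic acid on the thiophen-2-yl ring would do to the inhibition.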